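The compounds below may be only part of what the source reports. "The series", "measured", "known", "first", "only" and "open" are said of these compounds alone.

Measured compounds:
compound 1 `CNc1nc(-c2ccccc2)nc2c1nnn2Cc1ccccc1Cl`: 191000000 nM
compound 2 `CNc1nc(-c2ccccc2)nc2c1nnn2Cc1ccccc1F`: 25000000 nM
compound 3 `Clc1ccccc1Cn1nnc2c(NC3CCC3)nc(-c3ccccc3)nc21`: 24000000 nM

All three numbers come from an assay on isolated protein for binding affinity to adenosine receptor A1 (Bos taurus); a higher number here means a weaker inhibitor, a lower number a stronger inhibitor. Compound 2 stands second highest of the three: its nearest neighbour is compound 3, whose number is within the scatter of it, and the furthest is compound 1, separated by a 7.6-fold lower number from compound 1 to compound 2 (0.88 log units; beyond the scatter). Within the data shown here, the only change at the amine so far is an 8.0-fold lower number from compound 1 to compound 3 (0.90 log units; beyond the scatter), which shows that the group on that nitrogen does move the number.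

The next compound, compound 4 `OCCCNc1nc(-c2ccccc2)nc2c1nnn2Cc1ccccc1F`, differs from compound 2 by 2-hydroxyethyl in place of hydrogen on a saturated chain carbon bound to a nitrogen on an aromatic ring. Among the measured compounds shown here, no measured step carries a 2-hydroxyethyl into this series, and no step couples a chain extension with a hydroxyl group; the one step on the amine, from methyl to cyclobutyl, changes a different feature. The expectation for this assay is therefore a modest step at most, direction uncertain, estimated as a 1.7-fold lower number from compound 2 to compound 4 (0.22 log units; within the scatter). Compound 4 is expected to give 15000000 nM, within 3000000 nM to 80000000 nM.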

Compound 4, inhibition constant: 3700000 nM
Estimate against measurement, compound 4: 4.1-fold (0.61 log units) above; the range from low to high includes it.
By their numbers in this assay, from the lowest: compound 4; then compounds 3 and 2 (each within the scatter of the next); then compound 1.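

In this assay, the amine position proves responsive in the fluoro compounds as well, with 3-hydroxypropyl on the nitrogen in place of methyl giving (a 6.8-fold lower number from compound 2 to compound 4 (0.83 log units; beyond the scatter)). Among these compounds, the only earlier step at this nitrogen, from methyl to cyclobutyl (an 8.0-fold lower number from compound 1 to compound 3 (0.90 log units; beyond the scatter)), came from the chloro compounds and involved a ring without a hydroxyl, so a lower number is now seen with two different amine groups on two different benzyl-type partners. No supporting evidence bears on why this change moves the number.

The compounds shown do not separate the contribution of the longer chain from that of the hydroxyl, which a plain propyl group would address. Also open, going by these compounds, is whether an amine or a carboxylic acid in place of the hydroxyl would give a similar step.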